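A few compounds are considered here, and "the series" means these few. Any claim that something is new, unique, unknown or untested is made for them only; others in the source may bear on it.

Measured compounds:
compound 1 `O=C(CSc1nc(Nc2ccccc2)c2ccccc2n1)Nc1ccc([N+](=O)[O-])cc1` gives 25000 nM in a functional assay on PC-3 cells (Homo sapiens) for inhibition, read by MTT assay, with a stated time of 72 h; a lower number here means a stronger inhibitor, a higher number a weaker inhibitor
compound 2 `C=CC(=O)Nc1cccc(NC(=O)CSc2nc(Nc3ccccc3F)c3ccccc3n2)c1` gives 9340 nM

Going by the values given here, compound 2 has the lower of the two numbers recorded so far, and compound 1, its only neighbour, sits above it by a gap that lies beyond the usual scatter of repeated measurements. The two compounds differ in more than one place, so their values only show that compound 2 is the stronger inhibitor of the pair, not which part of the structure accounts for that.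

Compound 3 `C=CC(=O)Nc1cccc(NC(=O)CSc2nc(Nc3cccc([N+](=O)[O-])c3)c3ccccc3n2)c1` has not yet been measured. It is built from compound 2 by one change: 3-nitrophenyl in place of 2-fluorophenyl on a nitrogen on an aromatic ring. Among the compounds with values here, no step between measured compounds that differ in only one place is available, so there is no direct precedent for what a swap at this nitrogen does in this assay.

With nothing to anchor the direction, a small step is expected, most likely within the scatter and leaning towards a slightly higher number. Compound 3 is therefore estimated to give about 12000 nM, with a range from 4000 nM to 40000 nM. That estimate corresponds to an expected step of a 1.3-fold higher number from compound 2 to compound 3 (0.11 log units; within the scatter).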

Compound 3, half-maximal inhibitory concentration: 46300 nM
Beside the measured number, compound 3's estimate is 3.9-fold (0.59 log units) below it; the whole stated range lies below it.
By their numbers in this assay, from the lowest: compound 2; then compounds 1 and 3 (each within the scatter of the next).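

Going by these compounds alone, this is the first comparison in this assay in which only one place changes, so the effect of a single swap can finally be read: 3-nitrophenyl in place of 2-fluorophenyl on a nitrogen on an aromatic ring gives a 5.0-fold higher number from compound 2 to compound 3 (0.70 log units; beyond the scatter) in this pair. The group on this nitrogen is therefore not a silent part of the molecule, since replacing it while the rest of compound 2 stays the same is enough to weaken inhibition by more than repeat measurements would normally scatter. No measurement shown here accounts for the shift.

This single pair swaps the substituent and its printed ring position together, so it cannot separate the effect of nitro versus fluorine from the effect of where each one sits on the phenyl ring. It also gives only one direction from one starting point, leaving open how this nitrogen would respond to a phenyl ring carrying an amine or a carboxylic acid, or to a longer chain in place of the ring.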